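This account rests on a few compounds, and the source may have more. Where it says the series, first, only, none or still open, it means among the compounds named here.

Compound 1 `C[C@@H](Sc1nc2c(cnn2C)c(=O)n1-c1ccccc1)c1ccccc1`: 0.133 h
Compound 2 `CC(Sc1nc2c(cnn2C)c(=O)n1-c1ccccc1)c1cccc(O)c1`: 0.0667 h

In an ADME assay on microsomes from liver (Mus musculus, strain CD-1) for metabolic stability, read by LC-MS, with a stated time of 60 min, tested at 20 uM (on this read-out higher numbers stand for a longer-lived compound and lower numbers for a shorter-lived compound), compound 2 at 0.0667 h lies within the scatter of compound 1 at 0.133 h. Compound 3 `CC(Sc1nc2c(cnn2C)c(=O)n1-c1ccccc1)c1cncnc1` departs from compound 2 by pyrimidin-5-yl in place of 3-hydroxyphenyl on a saturated chain carbon bound to a saturated chain carbon and a sulfur, with pyrimidin-5-yl in place of 3-hydroxyphenyl on a saturated chain carbon bound to a saturated chain carbon and a sulfur. Among the compounds with values here, the only measured step available, a 2.0-fold lower number from compound 1 to compound 2 (0.30 log units; within the scatter), stays within the scatter, so no step beyond the scatter is expected here. The estimated step is a 1.8-fold higher number from compound 2 to compound 3 (0.26 log units; within the scatter). For compound 3 the expected half-life is 0.12 h, with an estimated range of 0.05 h to 0.35 h.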

Compound 3, half-life: 0.133 h
Beside the measured number, compound 3's estimate is 1.1-fold (0.04 log units) below it; measured number inside the range.
By their numbers in this assay, from the lowest: compounds 2, 1 and 3 (each within the scatter of the next).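

With pyrimidin-5-yl on the saturated chain carbon bound to a saturated chain carbon and a sulfur, this assay gives a 2.0-fold higher number from compound 2 to compound 3 (0.30 log units; within the scatter) for this exchange. The comparison with the 1-phenylethyl group gives no change at the digits printed from compound 1 to compound 3 (within the scatter) at the same sulfur, so a ring with hetero atoms is now also seen here, with no step beyond the scatter among the three compounds. Nothing measured here offers an explanation of these readings. Still open, as far as these compounds go, is whether an amine or a carboxylic acid on that ring would give a step beyond the scatter.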